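Swapping the Alkene Tail of a Weak Anilide Series

A few compounds are considered here, and "the series" means these few. Any claim that something is new, unique, unknown or untested is made for them only; others in the source may bear on it.

Compound 3 `C/C=C/C(=O)Nc1cccc(Oc2nc(Nc3cccc(C#N)c3)nc3ccsc23)c1` is tested in a functional assay on MCF7 cells (Homo sapiens) for inhibition, read by MTT assay, with a stated time of 72 h (on this read-out higher numbers stand for weaker inhibition and lower numbers for stronger inhibition), where compound 3 gives 33100 nM, the lowest of the two numbers shown. Compound 1 `COc1cccc(Nc2nc(Oc3cccc(NC(=O)C=C(C)C)c3)c3sccc3n2)c1` gives 35800 nM in this assay, a number within the usual scatter of compound 3. Compound 2 `COc1ccc(Nc2nc(Oc3cccc(NC(=O)C=C(C)C)c3)c3sccc3n2)cn1` gives > 100000 nM, which is a limit of this assay and not a number (the limit of > 100000 nM in this assay, at which 1 of the 3 values shown sits). Within the data shown here, the one measured step, an at least 2.7-fold higher number from compound 1 to compound 2 (0.44 log units; beyond the scatter), concerns the aromatic amine and not the amide tail. Compound 4 `CC(C)=CC(=O)Nc1cccc(Oc2nc(Nc3cccc(C#N)c3)nc3ccsc23)c1` differs from compound 3 only by 2-methylprop-1-en-1-yl in place of prop-1-en-1-yl on a carbonyl carbon. Among the measured compounds shown here, no measured step bears on this change, so no shift beyond the scatter is expected. Compound 4 is therefore estimated at 35000 nM, with a range from 12000 nM to 100000 nM. The expected step is a 1.1-fold higher number from compound 3 to compound 4 (0.02 log units; within the scatter).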

Compound 4, half-maximal inhibitory concentration: 41100 nM
Estimate against measurement, compound 4: 1.2-fold (0.07 log units) below; measured number inside the range.
By their numbers in this assay, from the lowest: compounds 3, 1 and 4 (each within the scatter of the next). At a limit, above all of these: compound 2.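

On the carbonyl carbon, 2-methylprop-1-en-1-yl and prop-1-en-1-yl cannot be told apart here, with a 1.2-fold higher number from compound 3 to compound 4 (0.09 log units; within the scatter). With the 2-methylprop-1-en-1-yl tail kept, cyano in place of methoxy on an aromatic carbon gives a 1.1-fold higher number from compound 1 to compound 4 (0.06 log units; within the scatter), while 3-cyanophenyl in place of 6-methoxypyridin-3-yl gives an at least 2.4-fold lower number from compound 2 to compound 4 (0.38 log units; beyond the scatter). The value of compound 2 in that last step is a limit, not a number: the limit of > 100000 nM in this assay, at which 1 of the 4 values shown sits.

The compounds shown leave open whether a tail with a longer chain or an amine would shift the number in this assay beyond the scatter.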